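Shortening the linker to the phenyl ring

The compounds below may be only part of what the source reports. "The series", "measured", "known", "first", "only" and "open" are said of these compounds alone.

For the measured compounds named here, compound 2 `Clc1ccnc2cc(OCCCc3ccccc3)ccc12` is the only compound with a full number in a functional assay on SK-OV-3 cells (Homo sapiens) for cytotoxicity, read by MTT assay, with a stated time of 48 h (a higher number here means a weaker inhibitor, a lower number a stronger inhibitor), where compound 2 gives 3610 nM. Compound 1 `CCCCCCOc1ccc2c(Cl)ccnc2c1` reaches only a limit, > 10000 nM in this assay. Going by the values given here, the step of an at least 2.7-fold lower number from compound 1 to compound 2 (0.44 log units; beyond the scatter) is the single measured comparison, and its size is bounded by the limit of > 10000 nM in this assay, at which 1 of the 2 values shown sits. Among the compounds with values here, compound 3 `Clc1ccnc2cc(OCCc3ccccc3)ccc12` differs from compound 2 by phenyl in place of benzyl on a saturated chain carbon, two bonds along the chain from an oxygen on an aromatic ring; no measured step tests a shorter chain, so in this assay the change a 1.1-fold higher number from compound 2 to compound 3 (0.04 log units; within the scatter) is expected to stay within the scatter. Compound 3 is therefore estimated at 4000 nM, in the range 1500 nM to 12000 nM.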

Compound 3, half-maximal inhibitory concentration: 2010 nM
The estimate for compound 3 lay 2.0-fold (0.30 log units) above the measured number, and the stated range covers the measured number.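

Shortening the link with phenyl in place of benzyl gives a 1.8-fold lower number from compound 2 to compound 3 (0.25 log units; within the scatter), so in this assay this position tolerates the change without a difference that can be told from the scatter. The step with phenyl in place of butyl, an at least 4.9-fold lower number from compound 1 to compound 3 (0.69 log units; beyond the scatter), lies beyond the scatter, so the advantage of a chain ending in an aromatic ring holds at this shorter length as well. The size of that step is open-ended: the limit of > 10000 nM in this assay, at which 1 of the 3 values shown sits.

Still open, as far as these compounds go, is whether an amine at the chain end, or a phenyl ring carrying a fluorine, would move the number beyond the scatter.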